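A few compounds are considered here, and "the series" means these few. Any claim that something is new, unique, unknown or untested is made for them only; others in the source may bear on it.

Compound 1, `O=C(Nc1nc(-c2cccc(Br)c2)cs1)c1ccc([N+](=O)[O-])o1`, was measured in an ADME assay on Vero cells (Chlorocebus sabaeus) for cytotoxicity, read by MTT assay, with a stated time of 72 h (on this read-out higher numbers stand for weaker inhibition and lower numbers for stronger inhibition), and gave 71000 nM. This is the highest of the two numbers recorded so far in this assay. Among the measured compounds shown here, the only other measured compound is compound 2, `Cc1cc(C)c(-c2csc(NC(=O)c3ccc([N+](=O)[O-])o3)n2)c(C)c1`, which in this assay gave 30400 nM; the two values differ by more than the usual scatter, so compound 1 shows the weaker inhibition of the pair. For the measured compounds named here, no pair differing in a single place has yet been measured, so no step in this assay is known.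

Compound 3, `O=C(Nc1cccc(-c2csc(NC(=O)c3ccc([N+](=O)[O-])o3)n2)c1)c1ccccc1`, has not yet been measured. It differs from compound 1 by benzamido in place of bromo on an aromatic carbon. Going by the values given here, with no measured step of this kind to lean on, the expectation rests only on the two values already in hand, and a modest shift toward a lower number in this assay seems the most plausible outcome, though one that may well remain within the scatter. The step from compound 1 to compound 3 expected in this assay is a 1.4-fold lower number from compound 1 to compound 3 (0.15 log units; within the scatter). For compound 3 the estimated value in this assay is 50000 nM, within a range from 20000 nM to 120000 nM.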

Compound 3, half-maximal inhibitory concentration: 50200 nM
Compound 3: the middle estimate sits 1.0-fold (0.00 log units) below what was measured; low and high end bracket the measured number.
By their numbers in this assay, from the lowest: compounds 2, 3 and 1 (each within the scatter of the next, the first and the last beyond it).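

Swapping bromo for benzamido on this aromatic carbon gives a 1.4-fold lower number from compound 1 to compound 3 (0.15 log units; within the scatter) in this assay, the first step known at this position. The place, meta to a large group, therefore takes a much larger group, one that brings in a six-membered aromatic ring of carbon only together with a hydrogen-bond donor and acceptor, with no shift beyond the scatter in this read-out. No measured evidence is available that bears on this result.

On these data alone, whether an amine or a carboxylic acid on this aromatic carbon would give a step beyond the scatter remains open. As far as these compounds go, it is also open whether the added ring of the benzamido group counts for anything on its own, which an acetamido group in the same place would help to show, and whether this single step would hold on any core other than that of compound 1.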